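The compounds below may be only part of what the source reports. "The series", "measured", "known", "first", "only" and "open" are said of these compounds alone.

Measured so far in a functional assay on the whole organism (strain Swiss) with Mus musculus as the target, in the maximal electroshock model, with a stated time of 1 h, at a dose of 300 mg/kg by the intraperitoneal route; on this read-out higher numbers stand for a stronger effect at the one dose given and lower numbers for a weaker effect:
- compound 1 `CC(C(=O)N1CCN(c2ccccc2)CC1)N1C(=O)CCC1=O` gives 50%
- compound 2 `CC(C(=O)N1CCN(c2ccc(Cl)cc2)CC1)N1C(=O)CCC1=O` gives 0%
- compound 3 `CCC(C(=O)N1CCN(c2cccc(F)c2)CC1)N1C(=O)CCC1=O` gives 75%

Compound 3 stands highest of the three numbers; its nearest neighbour is compound 1, and the furthest is compound 2, both of them lower by more than the scatter. For the measured compounds named here, the only single-point step among the measured compounds is a number 50 percentage points lower from compound 1 to compound 2 (beyond the scatter), a large fall. The next compound, compound 4 `CC(C(=O)N1CCN(c2cccc(F)c2)CC1)N1C(=O)CCC1=O`, has not yet been measured. It differs from compound 3 by hydrogen in place of methyl on a saturated chain carbon, two bonds along the chain from an amide-type nitrogen in a ring and a carbonyl carbon.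

Going by the values given here, no measured step bears directly on this change: the one step known concerns the aromatic ring, not the chain, and compounds 1 and 3, which differ in the chain, also differ on the ring, so their values alone cannot separate the two changes. What the numbers show is that the two methyl compounds, compound 1 and compound 2, sit below the ethyl compound 3, and that compound 1 on its own reaches a middling number. For compound 4 the expectation is therefore a step downward, a number 25 percentage points lower from compound 3 to compound 4 (beyond the scatter), with wide uncertainty. Compound 4 is estimated at 50%, within a range of 25% to 75%, before the measurement is known.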

Compound 4, a percentage reported as activity, at one dose (the size of the read-out at that dose, not a potency): 75%
The estimate for compound 4 lay 25 percentage points below the measured number; low and high end bracket the measured number.
By their numbers in this assay, from the lowest: compound 2; then compound 1; then compounds 3 and 4 (each within the scatter of the next).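

In this assay, for the compounds shown here, the change from ethyl to methyl on the saturated chain carbon, with the 3-fluorophenyl group held constant, gives no change at the digits printed from compound 3 to compound 4 (within the scatter) and is the first reading of this chain position on its own. With methyl fixed on the chain, the aromatic ring can also be read separately: going from an unsubstituted phenyl to the 3-fluorophenyl group gives a number 25 percentage points higher from compound 1 to compound 4 (beyond the scatter) and 3-fluorophenyl in place of 4-chlorophenyl on the amine nitrogen in a ring gives a number 75 percentage points higher from compound 2 to compound 4 (beyond the scatter), so in these compounds the ring changes shift the read-out while the chain change does not. Nothing available here accounts for either the flat chain step or the ring steps.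

On these data alone, the flat chain step rests on one pair carrying the 3-fluorophenyl group, so it remains open whether ethyl and methyl would also match with an unsubstituted phenyl or a 4-chlorophenyl group on the same core. Also open, as far as these compounds go, is how a longer chain such as propyl, or hydrogen alone on that carbon, would read, and since each number comes from a single dose, compound 3 and compound 4 could still differ in the strength of their effect at other doses.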